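Replacing the pyrrolidine on the shared core with a fused bicyclic amine

The source may hold more compounds than are shown below. What is called first, only, known or untested is meant among the compounds shown, and "the series" means these compounds.

Measured in an assay on HEK293 cells for inhibition of Fatty-acid amide hydrolase 1 (Homo sapiens), read by fluorescence; a lower number here means a stronger inhibitor, a higher number a weaker inhibitor:
- compound 1 `COc1ccc(Nc2nc3cc(-c4ccc5c(ccn5C)c4)ccc3o2)cc1`: 280 nM
- compound 2 `Cn1ccc2cc(-c3ccc4oc(Nc5ccccn5)nc4c3)ccc21`: 186 nM
- compound 3 `Cn1ccc2cc(-c3ccc4oc(N5CCCC5)nc4c3)ccc21`: 674 nM

Compound 3 gives the highest number of the three: a 2.4-fold higher number from compound 1 to compound 3 (0.38 log units; beyond the scatter) and a 3.6-fold higher number from compound 2 to compound 3 (0.56 log units; beyond the scatter), both beyond the scatter, while compound 1 and compound 2 sit within scatter of each other, a 1.5-fold lower number from compound 1 to compound 2 (0.18 log units; within the scatter).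

Compound 4 `Cn1ccc2cc(-c3ccc4oc(N5Cc6ccncc6C5)nc4c3)ccc21` differs from compound 3 by a group of 9 heavy atoms (7 carbon, 2 nitrogen; one five-membered non-aromatic ring with 1 hetero atom, one six-membered aromatic ring with 1 hetero atom) in place of a group of 5 heavy atoms (4 carbon, 1 nitrogen; one five-membered non-aromatic ring with 1 hetero atom), on an aromatic carbon. Among the measured compounds shown here, no measured step covers this exchange; the two beyond-scatter steps concern swapping the pyrrolidin-1-yl for arylamino groups, each giving a lower number. Compound 4 keeps a cyclic amine but adds the six-membered aromatic ring, so only a modest move is expected: compound 4 is estimated at 420 nM (range 140 nM to 1300 nM), the expected step of a 1.6-fold lower number from compound 3 to compound 4 (0.21 log units; within the scatter) lying near the scatter.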

Compound 4, half-maximal inhibitory concentration: 121 nM
Compound 4: the middle estimate sits 3.5-fold (0.54 log units) above what was measured; the whole stated range lies above it.
By their numbers in this assay, from the lowest: compounds 4, 2 and 1 (each within the scatter of the next, the first and the last beyond it); then compound 3.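

In this assay, a cyclic amine at this position, on an aromatic carbon, need not give a high number: adding the six-membered aromatic ring to the five-membered ring gives a 5.6-fold lower number from compound 3 to compound 4 (0.75 log units; beyond the scatter). An arylamino group is therefore not required at this position, since a 1.5-fold lower number from compound 2 to compound 4 (0.19 log units; within the scatter) and a 2.3-fold lower number from compound 1 to compound 4 (0.36 log units; beyond the scatter). No evidence is available to explain these steps.

Going by these compounds, it remains open whether isoindolin-2-yl, the same fused amine with only carbon in its aromatic ring, would match compound 4. On these data alone, the effect of a morpholine at this position also remains open.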